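Working notes on chloro substitution and partition in a small series

This account rests on a few compounds, and the source may have more. Where it says the series, first, only, none or still open, it means among the compounds named here.

Measured so far in a physicochemical assay for lipophilicity, in phosphate buffer, measured as octanol-water partition, with a stated time of 24 h; on this read-out higher numbers stand for higher lipophilicity and lower numbers for lower lipophilicity:
compound 1, `Cc1ccc(Oc2ccc(/C=N/NC(=S)Nc3ccccc3)cc2)cc1`: 5.39
compound 2, `Cc1ccc(Oc2ccc(/C=N/NC(=S)Nc3ccc(Cl)cc3)cc2)cc1`: 5.97
compound 3, `Cc1cc(Oc2ccc(/C=N/NC(=S)Nc3ccccc3)cc2)ccc1Cl`: 6.03

Compound 2 differs from compound 1 by chloro in place of hydrogen on an aromatic carbon. In this assay this change made a step of a number 0.58 log units higher from compound 1 to compound 2 (beyond the scatter). Compound 3 differs from compound 1 by 4-chloro-3-methylphenyl in place of 4-methylphenyl on an oxygen on an aromatic ring, and in this assay the step was a number 0.64 log units higher from compound 1 to compound 3 (beyond the scatter). Compound 2 and compound 3 lie within the usual scatter of each other, so nothing is said here about their order.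

Compound 4, `Cc1cc(Oc2ccc(/C=N/NC(=S)Nc3ccc(Cl)cc3)cc2)ccc1Cl`, has not yet been measured in this assay. It differs from compound 3 by chloro in place of hydrogen on an aromatic carbon. This is the same change as that from compound 1 to compound 2, and the place it sits in is described in the same words in both pairs. The cores of the two pairs differ by 4-chloro-3-methylphenyl in place of 4-methylphenyl on an oxygen on an aromatic ring as set out above; this is the only difference between them.

Because the change gave a number 0.58 log units higher from compound 1 to compound 2 (beyond the scatter) on the core of compound 1, a step of similar size is expected on the core of compound 3, namely a number 0.57 log units higher from compound 3 to compound 4 (beyond the scatter). This rests on a single earlier instance and on the cores differing only by the change just named, so the range is kept fairly wide. Compound 4 is thus expected to give about 6.6 in this assay, most likely between 6.3 and 6.9.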

Compound 4, partition coefficient: 6.59
Compound 4: middle estimate off by 0.01 log units, on the high side; low and high end bracket the measured number.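

In this assay, chloro in place of hydrogen on an aromatic carbon gave a number 0.56 log units higher from compound 3 to compound 4 (beyond the scatter), close in size to the earlier a number 0.58 log units higher from compound 1 to compound 2 (beyond the scatter), so this change carried over from one core to the other in the one case available. Read the other way, the same four compounds show the second change also holding its size across the two cores, with a number 0.62 log units higher from compound 2 to compound 4 (beyond the scatter) against the earlier a number 0.64 log units higher from compound 1 to compound 3 (beyond the scatter); no compound shown goes against this pattern, but it rests on this single set of four and does not show that the steps would add up in the same way on any other core. Nothing shown explains why the steps agree.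

The compounds shown leave open whether a step of this size would appear with an amine or a carboxylic acid in place of the chloro, since chloro is the only group shown entering at that aromatic carbon. They also leave open whether the agreement would survive a longer chain, such as propyl, in place of the methyl on the other end of the molecule.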